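A few compounds are considered here, and "the series" means these few. Any claim that something is new, unique, unknown or untested is made for them only; others in the source may bear on it.

Compound 3 `C=C(Br)C(=O)Nc1cccc(-c2cn3nc(Cc4ccccc4)sc3n2)c1` gives 4500 nM in a functional assay on HeLa cells (Homo sapiens) for inhibition, read by cell counting, with a stated time of 4 days; on this read-out lower numbers stand for stronger inhibition and higher numbers for weaker inhibition. Among the three measured compounds it holds the highest number, but the others stand close: compound 1 `C=C(Br)C(=O)Nc1cccc(-c2cn3nc(-c4ccc(CC)cc4)sc3n2)c1` gives 3200 nM, and compound 2 `C=C(Br)C(=O)Nc1cccc(-c2cn3nc(Cc4cccc(OC)c4)sc3n2)c1` gives 2500 nM. The steps of a 1.4-fold higher number from compound 1 to compound 3 (0.15 log units; within the scatter) and a 1.8-fold higher number from compound 2 to compound 3 (0.26 log units; within the scatter) both lie within the scatter, as does a 1.3-fold lower number from compound 1 to compound 2 (0.11 log units; within the scatter), so the three numbers cannot be set in order.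

Compound 4 `Nc1cccc(-c2cn3nc(Cc4ccccc4)sc3n2)c1` has not yet been measured. Its difference from compound 3 is hydrogen in place of (1-bromoethenyl)carbonyl on a nitrogen on an aromatic ring; cut one bond further out, the same difference reads ((1-bromoethenyl)carbonyl)amino to amino. None of the three measured steps bears on this change. Each of them altered the group on the far side of the shared core and left the amide untouched, and each stayed within the scatter. Going by the values given here, the measured set therefore gives no step from which the size of this change can be read, and the change itself removes a larger piece than any measured step moved.

With nothing to anchor it, compound 4 is expected to give a higher number than compound 3, by a step of about a 3.3-fold higher number from compound 3 to compound 4 (0.52 log units; beyond the scatter), and this expectation carries a wide range. The estimate for compound 4 in this assay is 15000 nM, between 4000 nM and 60000 nM.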

Compound 4, half-maximal inhibitory concentration: 24000 nM
Estimate against measurement, compound 4: 1.6-fold (0.20 log units) below, within the range that was stated.
By their numbers in this assay, from the lowest: compounds 2, 1 and 3 (each within the scatter of the next); then compound 4.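

Going by these compounds alone, the step of a 5.3-fold higher number from compound 3 to compound 4 (0.73 log units; beyond the scatter) in this assay is the first in this set to lie beyond the scatter, and it is also the first change on a nitrogen on an aromatic ring, whereas the three earlier steps, all within the scatter, changed only the benzyl, 3-methoxybenzyl or 4-ethylphenyl group. The number in this assay therefore responds to the exchange of ((1-bromoethenyl)carbonyl)amino for amino more clearly than to any of those earlier exchanges, yet the step is modest and compound 4, with the plain amino group, still gives a measured 24000 nM. Nothing shown here explains why the number moves with this change.

From the compounds shown here alone, the (1-bromoethenyl)carbonyl group left as a whole, so it remains open whether the step follows the bromine, the carbon-carbon double bond or the carbonyl, and an acetyl or an unbrominated propenoyl group on the same nitrogen would separate these parts. Going by these compounds, it also remains open whether the step is the same size with 4-ethylphenyl or 3-methoxybenzyl in place of benzyl.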